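Adding a second chloro to a weak amine oxidase inhibitor

This account rests on a few compounds, and the source may have more. Where it says the series, first, only, none or still open, it means among the compounds named here.

Three sulfonamide-bearing compounds have been tested in an assay on cells for inhibition of Amine oxidase [flavin-containing] A (Homo sapiens), read by fluorescence and spectrophotometry, using microsomes, with a stated time of 20 min; a lower number here means a stronger inhibitor, a higher number a weaker inhibitor. Compound 1, `NS(=O)(=O)c1cccc(-c2nnc(-c3ccc(F)cc3)o2)c1`, gives 34400 nM. Compound 2, `NS(=O)(=O)c1ccc(C(=O)NNC(=O)c2ccc(Cl)cc2)cc1`, gives 55900 nM. Compound 3, `NS(=O)(=O)c1ccc(-c2nnc(-c3ccccc3)o2)cc1`, gives 63900 nM. All three numbers are high, so each compound is a weak inhibitor. On the numbers shown, compound 2 stands second highest of the three, yet its gap to compound 3, the nearest, and its gap to compound 1, the furthest, both lie within the usual scatter of this assay, so the three compounds cannot be told apart on potency.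

Compound 4, `NS(=O)(=O)c1ccc(C(=O)NNC(=O)c2ccc(Cl)c(Cl)c2)cc1`, differs from compound 2 in one place: chloro in place of hydrogen on an aromatic carbon. The new chloro enters on an aromatic carbon of a six-membered aromatic ring of carbon only, ortho to a chloro group already present, so the 4-chlorophenyl end becomes 3,4-dichlorophenyl.

Going by the values given here, no pair of measured compounds shows the effect of such a change, so there is nothing to anchor a direction. A single added chloro is a small change, and the expected step of a 1.4-fold lower number from compound 2 to compound 4 (0.15 log units; within the scatter) is taken to be small, not clearly beyond the scatter. Compound 4 is therefore estimated at 40000 nM, with a range from 15000 nM to 110000 nM.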

Compound 4, half-maximal inhibitory concentration: 13600 nM
Compound 4: the middle estimate sits 2.9-fold (0.47 log units) above what was measured; measured number below the stated range.
By their numbers in this assay, from the lowest: compound 4; then compounds 1, 2 and 3 (each within the scatter of the next).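

Chloro in place of hydrogen on this aromatic carbon, ortho to a chloro group and meta to a large group, gives a 4.1-fold lower number from compound 2 to compound 4 (0.61 log units; beyond the scatter) in this assay. Going by these compounds alone, this is the first step that can be read at all, and it shows that this position is not silent: one added chlorine atom on the 4-chlorophenyl end moves the number by more than the scatter, although compound 4, at 13600 nM, is still a weak inhibitor. Nothing measured here explains why the 3,4-dichlorophenyl end gives the lower number.

One pair cannot show whether the gain belongs to chloro itself, or whether another group on the same carbon, such as a methyl or a methoxy, would give a similar step. From the compounds shown here alone, it also remains open whether the step depends on the chloro group already present, and whether it would carry over to the compounds whose core holds a ring in place of the open chain joining the two aromatic ends.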